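This account rests on a few compounds, and the source may have more. Where it says the series, first, only, none or still open, it means among the compounds named here.

In a functional assay on MCF7 cells (Homo sapiens) for inhibition, read by sulforhodamine B assay, with a stated time of 72 h (on this read-out lower numbers stand for stronger inhibition of growth and higher numbers for weaker inhibition of growth), three compounds have been measured:

- compound 1 (`O=C(O)/C=C/c1ccncc1-c1ccc2ccccc2c1`) gives > 10000 nM
- compound 2 (`COC1CN(C(=O)/C=C/c2ccncc2-c2ccc3ccccc3c2)C1`) gives > 10000 nM
- compound 3 (`Cn1ccc2cc(-c3cnccc3/C=C/C(=O)O)ccc21`) gives > 10000 nM

Each of these is a limit and not a number. Compound 2 therefore has no exact place and shares its position with the other two (the limit of > 10000 nM in this assay, at which 3 of the 3 values shown sit). Compound 4 (`O=C(/C=C/c1ccncc1-c1ccc2ccccc2c1)NC1CC1`) carries cyclopropylamino in place of 3-methoxyazetidin-1-yl on a carbonyl carbon. Going by the values given here, the one measured step at this carbonyl carbon is a step that the two limits leave unreadable from compound 1 to compound 2 and offers no size to carry over. No step beyond the scatter is expected in this assay in either direction. The expected change is a step that the limit leaves unreadable from compound 2 to compound 4 and no more than that. Compound 4 is estimated at 15000 nM with an expected range from 5000 nM to 40000 nM and may well return only a limit.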

Compound 4, concentration for 50% growth inhibition: 6840 nM
For compound 4 the middle estimate is 2.2-fold (0.34 log units) above the measured one, within the range that was stated.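

In this assay, going by these compounds alone, compound 4 is the first compound with an exact number rather than a limit, so cyclopropylamino on this carbonyl carbon gives the series a measurable starting point. The printed steps are an at least 1.4-fold lower number from compound 2 to compound 4 (0.16 log units; that floor lies within the scatter) and an at least 1.4-fold lower number from compound 1 to compound 4 (0.16 log units; that floor lies within the scatter); these are only floors, and the true gaps may be larger. The other compounds still give no exact value: the limit of > 10000 nM in this assay, at which 3 of the 4 values shown sit.

From the compounds shown here alone, it remains open whether the three-membered ring or the amide hydrogen matters more. Methylamino or cyclobutylamino at this carbonyl carbon could begin to separate the two.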